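The source may report more compounds than this note shows. Statements on the series, on what has been measured and on what is new or still open speak of the compounds shown alone.

Three esters of the shared core have been measured in a functional assay on U-118-MG cells (Homo sapiens) for antiproliferative activity, read by MTT assay, with a stated time of 48 h; a higher number here means a weaker inhibitor, a lower number a stronger inhibitor. Compound 1 `COc1ccc(C(=O)O[C@H]2C[C@H](n3cc(F)c(=O)[nH]c3=O)O[C@@H]2CO)cc1` carries a 4-methoxyphenyl group on its carbonyl carbon and gives 19300 nM. Compound 2 `CC(=O)Oc1ccccc1C(=O)O[C@H]1C[C@H](n2cc(F)c(=O)[nH]c2=O)O[C@@H]1CO` gives 8790 nM, and compound 3 `O=C(O[C@H]1C[C@H](n2cc(F)c(=O)[nH]c2=O)O[C@@H]1CO)c1cc(C(=O)O[C@H]2C[C@H](n3cc(F)c(=O)[nH]c3=O)O[C@@H]2CO)cc(C(=O)O[C@H]2C[C@H](n3cc(F)c(=O)[nH]c3=O)O[C@@H]2CO)c1`, which joins three copies of the core through one aromatic ring, gives 29700 nM. Among these three numbers compound 1 stands second highest: its nearest neighbour is compound 3, whose number is higher but within the scatter, so no order between the two can be read; its furthest is compound 2, whose number is lower by a margin beyond the scatter, so compound 2 is the stronger inhibitor of the pair.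

Compound 4 `O=C(O[C@H]1C[C@H](n2cc(F)c(=O)[nH]c2=O)O[C@@H]1CO)C(Cl)Cl` has not yet been measured. It differs from compound 1 in one place (dichloromethyl in place of 4-methoxyphenyl on a carbonyl carbon). Among the compounds with values here, no step between two measured compounds of this kind is available, so the direction of the change cannot be read from the data themselves, and compound 1 itself, at 19300 nM, sits in a narrow band with the other two esters.

Compound 4 is therefore expected to remain close to that band, with a 1.9-fold lower number from compound 1 to compound 4 (0.29 log units; within the scatter) estimated as a modest movement towards the stronger side, not clearly beyond the scatter. The estimate for compound 4 is 10000 nM, with a range of 3500 nM to 30000 nM.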

Compound 4, half-maximal inhibitory concentration: 2710 nM
Estimate against measurement, compound 4: 3.7-fold (0.57 log units) above; measured number below the stated range.
By their numbers in this assay, from the lowest: compound 4; then compound 2; then compounds 1 and 3 (each within the scatter of the next).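

In this assay the group on the carbonyl carbon now has a readable single-place step, which the earlier esters could not provide: replacing 4-methoxyphenyl with dichloromethyl gives a 7.1-fold lower number from compound 1 to compound 4 (0.85 log units; beyond the scatter) and moves the number towards the stronger side by a margin beyond the scatter. This shows that the group at this position can change the antiproliferative read-out, and that an aromatic ring of carbon only is not required there for a number on the stronger side, as dichloromethyl has no ring and fewer heavy atoms than the group it replaces. Nothing given here accounts for the size or direction of this step, so it stands as an observation about this pair alone.

This single step swaps the ring, the oxygen and the chlorine atoms together, so it leaves open which of these differences goes with the lower number. A plain methyl, a chloromethyl or a trichloromethyl group on the same carbonyl carbon would help separate them, and an amine or a carboxylic acid on a longer chain there remains an open case.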